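Fluoro for methyl on a fatty acid receptor agonist

A few compounds are considered here, and "the series" means these few. Any claim that something is new, unique, unknown or untested is made for them only; others in the source may bear on it.

Measured so far:
Compound 1, `CC#CC(CC(=O)O)c1ccc(OCc2ccc3nc(-c4ccc(CC)cc4)cn3c2)cc1`: 496 nM
Compound 2, `CC#CC(CC(=O)O)c1ccc(OCc2ccn3cc(-c4ccc(C)cc4)nc3c2)cc1`: 618 nM
Compound 3, `CC#CC(CC(=O)O)c1ccc(OCc2ccc3nc(-c4ccc(C)cc4C)cn3c2)cc1`: 316 nM

All three were tested in an assay on isolated protein for agonist activity at Free fatty acid receptor 1 (Homo sapiens); a lower number here means that less compound is needed, a higher number that more compound is needed for the effect. Compound 2 stands close to the other two: its gaps to compound 1 and to compound 3 are both within the usual scatter of this assay, so the three numbers cannot be told apart with confidence.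

Compound 4, `CC#CC(CC(=O)O)c1ccc(OCc2ccn3cc(-c4ccc(F)cc4)nc3c2)cc1`, is not yet measured. It differs from compound 2 by one small exchange: fluoro in place of methyl on an aromatic carbon. Going by the values given here, the only measured step that touches the same outer ring is a 1.6-fold lower number from compound 1 to compound 3 (0.20 log units; within the scatter), which changed the substituents on that ring without moving the number beyond the scatter. Among the compounds with values here, no measured step exchanges methyl for fluoro, so the expectation rests on that single, flat step. The step from compound 2 to compound 4 is therefore expected to be small, a 1.0-fold lower number from compound 2 to compound 4 (0.01 log units; within the scatter), in no clear direction. Compound 4 is estimated at 600 nM in this assay, with a range from 250 nM to 1500 nM.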

Compound 4, half-maximal effective concentration: 783 nM
Beside the measured number, compound 4's estimate is 1.3-fold (0.12 log units) below it; the measured number falls inside the stated range.
By their numbers in this assay, from the lowest: compounds 3, 1, 2 and 4 (each within the scatter of the next, the first and the last beyond it).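

In this assay, the direct exchange of methyl for fluoro on this ring gives a 1.3-fold higher number from compound 2 to compound 4 (0.10 log units; within the scatter), so 4-methylphenyl and 4-fluorophenyl cannot be told apart here. This place, para to a large group, therefore holds either one without a step beyond the scatter. Nothing at hand gives a reason for this result. On these data alone, whether another group here, such as trifluoromethyl, methoxy or an amine, would move the number beyond the scatter remains open. So does whether fluoro gives a similarly small step on the core of compound 1.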